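Compound 3: what leaving benzoyl(methyl)amino may bring

The compounds below may be only part of what the source reports. "The series", "measured", "known", "first", "only" and "open" are said of these compounds alone.

Values in an ADME assay on microsomes from liver (Homo sapiens) for metabolic stability, read by LC-MS, using NADPH, with stated times of 5 min and 30 min, tested at 1 uM (a higher number here means faster removal of the compound, a lower number slower removal), so far:
Compound 1 `CN(c1ncco1)c1cnc(NCc2c(F)ccc3c2CCO3)n2cnnc12` gives 11 mL.min-1.g-1 as a number
Compound 2 `CN(C(=O)c1ccccc1)c1cnc(NCc2c(F)ccc3c2CCO3)n2cnnc12` gives > 300 mL.min-1.g-1 as a limit of the assay

Compound 2 has no number to its name and stands at a limit (the limit of > 300 mL.min-1.g-1 in this assay, at which 1 of the 2 values shown sits). Going by the values given here, one measured step bears on what comes next. That step is an at least 27-fold higher number from compound 1 to compound 2 (1.43 log units; beyond the scatter) and it is large, beyond the scatter, with benzoyl in place of 1,3-oxazol-2-yl on a nitrogen on an aromatic ring.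

Compound 3 `O=C(Nc1cnc(NCc2c(F)ccc3c2CCO3)n2cnnc12)c1cccnc1` also gives up that benzoyl, and the change is ((pyridin-3-yl)carbonyl)amino in place of benzoyl(methyl)amino on an aromatic carbon. The new group still holds a carbonyl, on a six-membered aromatic ring with 1 hetero atom, so the earlier step can only be a loose guide. Resting on that single step, a large move to a lower number is expected in this assay and not a return all the way. As far as these compounds go, the expected change is an at least 7.5-fold lower number from compound 2 to compound 3 (0.87 log units; beyond the scatter) as an estimate, and its true size stays open while compound 2 remains a limit. The estimated value in this assay for compound 3 is 40 mL.min-1.g-1 (expected range 10 mL.min-1.g-1 to 200 mL.min-1.g-1).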

Compound 3, intrinsic clearance in microsomes in the Homo sapiens assay: < 3 mL.min-1.g-1
Compound 3: only a limit was reported; the forecaster's own chance of this, stated with the estimate: 10%; middle value at least 13-fold (1.12 log units) away from the limit.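

With ((pyridin-3-yl)carbonyl)amino in place of benzoyl(methyl)amino on this aromatic carbon, the Homo sapiens assay shows an at least 100-fold lower number from compound 2 to compound 3 (2.00 log units; beyond the scatter), so a single change here can carry the read-out from one end of the values shown to the other. The new group also compares well with the methyl(1,3-oxazol-2-yl)amino group, with an at least 3.6-fold lower number from compound 1 to compound 3 (0.56 log units; beyond the scatter), which means that a five-membered oxazole is not needed at this place for slow removal. Compound 2 and compound 3 both hold a carbonyl, so a carbonyl here does not by itself go with fast removal, and compound 3 is also the less lipophilic of the pair, though only modestly: the measured distribution coefficient of compound 2, 2.4, and of compound 3, 2, a number 0.40 log units lower (beyond the scatter) In a physicochemical assay for lipophilicity, using the shake flask method, in phosphate buffer, measured as octanol-water partition, with a stated time of 30 min, at pH 7.4 (a lower number here means a more polar compound, a higher number a more lipophilic compound), compound 2 gives 2.4 and compound 3 gives 2.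

As far as these compounds go, in the Homo sapiens assay compound 3 is reported only as a limit, < 3 mL.min-1.g-1, so the true size of both steps stays open. The pyridin-3-yl ring and the amide hydrogen enter together, so the compounds shown do not say which of them goes with the drop, and what a small alkyl amide or a carboxylic acid would do on this aromatic carbon also remains open.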